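Benzyl ether variation in the acylurea series

This account rests on a few compounds, and the source may have more. Where it says the series, first, only, none or still open, it means among the compounds named here.

Going by the values given here, compound 2 `Cc1ccc(NC(=O)NC(=O)c2ccc(OCc3cccc(Cl)c3Cl)cc2)cc1-c1nc2ccccc2[nH]1` carries the higher of the two numbers so far in a functional assay on HT-29 cells (Homo sapiens) for inhibition, read by MTT assay, with a stated time of 48 h; on this read-out higher numbers stand for weaker inhibition and lower numbers for stronger inhibition; in this assay compound 2 gives 48500 nM. Among the compounds with values here, compound 1 `Cc1ccc(NC(=O)NC(=O)c2ccc(OCc3ccc(C(F)(F)F)cc3)cc2)cc1-c1nc2ccccc2[nH]1` is the only comparator: in this assay compound 1 gives 7830 nM, and the step of a 6.2-fold higher number from compound 1 to compound 2 (0.79 log units; beyond the scatter) is the single measured change at this position. Compound 3 `Cc1ccc(NC(=O)NC(=O)c2ccc(OCc3cccc(F)c3)cc2)cc1-c1nc2ccccc2[nH]1` differs from compound 2 by 3-fluorophenyl in place of 2,3-dichlorophenyl on a saturated chain carbon bound to an oxygen on an aromatic ring. Within the data shown here, the measured step from compound 1 to compound 2 bears on it only loosely, since it shows that exchanging substituents on this ring shifts the number by a modest amount; no step involving a 3-fluorophenyl group has been measured. For compound 3 a modest fall is therefore expected, a 3.2-fold lower number from compound 2 to compound 3 (0.51 log units; beyond the scatter), with wide uncertainty. The estimate for compound 3 in this assay is 15000 nM, with a range from 4000 nM to 60000 nM.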

Compound 3, half-maximal inhibitory concentration: 38200 nM
Beside the measured number, compound 3's estimate is 2.5-fold (0.41 log units) below it, within the range that was stated.
By their numbers in this assay, from the lowest: compound 1; then compounds 3 and 2 (each within the scatter of the next).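

In this assay, 3-fluorophenyl in place of 2,3-dichlorophenyl gives a 1.3-fold lower number from compound 2 to compound 3 (0.10 log units; within the scatter) and so does not separate these two groups at this position, on a saturated chain carbon bound to an oxygen on an aromatic ring. 3-Fluorophenyl in place of 4-(trifluoromethyl)phenyl gives a 4.9-fold higher number from compound 1 to compound 3 (0.69 log units; beyond the scatter) and so repeats the gap first seen with compound 2, leaving compound 1 as the only one of the three set apart by its number. No measurement on hand bears on what lies behind this gap.

Going by these compounds, it remains open whether the gap belongs to the trifluoromethyl group itself or to its place on the ring. Also open, on these data alone, is how a plain benzyl group, a methoxy-bearing benzyl group or a longer chain would compare with compound 1 at this position.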